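The compounds below may be only part of what the source reports. "The series", "measured", "known", "first", "only" and "open" are said of these compounds alone.

Working notes on the series. In an assay on isolated protein for inhibition of cytosolic endo-beta-N-acetylglucosaminidase (Homo sapiens), tested at 1000 uM (a lower number here means less inhibition, a higher number more inhibition at the concentration tested (going by the name of the read-out)), compound 2 `O=C(O)[C@H]1NC[C@H](O)[C@@H](O)[C@@H]1O` gives 43%, the highest of the three numbers measured; compound 1 `O=C(O)[C@@H]1NCC=C[C@@H]1O` gives 14% and compound 3 `O=C(O)[C@@H]1NCC=C[C@H]1O` gives 14%, both well below compound 2. Among the compounds with values here, the step of no change at the digits printed from compound 1 to compound 3 (within the scatter), where (the fact that compounds 1 and 3 differ only in the configuration as drawn), is the only one bearing on a change of configuration. Compound 4 `O=C(O)[C@@H]1NC[C@@H](O)[C@@H](O)[C@@H]1O` is not yet measured; it differs from compound 2 as follows: the two compounds have the same atoms and bonds and differ only in configuration as drawn: 2 of 4 stereo elements differ; a stereocentre at a saturated ring carbon is drawn S in compound 2 and R in compound 4; a stereocentre at a saturated ring carbon is drawn S in compound 2 and R in compound 4. With two stereocentres inverted rather than one, the pure stereochemical step from compound 1 to compound 3 is the nearest guide, and it suggests a step of a number 8 percentage points lower from compound 2 to compound 4 (within the scatter) that is expected to stay at or near the scatter, perhaps a modest loss. The value for compound 4 is therefore estimated at 35%, in the range 10% to 60%.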

Compound 4, a percentage reported as inhibition, at one concentration (the size of the read-out at that concentration, not a potency): 2.1%
Compound 4: middle estimate off by 32.9 percentage points, on the high side, outside the stated range (below it).
By their numbers in this assay, from the lowest: compound 4; then compounds 1 and 3 (each within the scatter of the next); then compound 2.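

In this assay, inverting two stereocentres gives a number 40.9 percentage points lower from compound 2 to compound 4 (beyond the scatter), with the same atoms and bonds throughout, so configuration alone can move this read-out by a large margin. The single inversion in the other pair gave no change at the digits printed from compound 1 to compound 3 (within the scatter), so the absence of a change there does not carry over to this pair. Which of the two inverted stereocentres accounts for the step stays open, as the two compounds differ at both. As far as these compounds go, whether a methyl ester or an amide in place of the carboxylic acid would retain the inhibition seen with compound 2 also stays open.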